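From 4-fluorophenyl to 3,4,5-trimethoxyphenyl on a shared core

This account rests on a few compounds, and the source may have more. Where it says the series, first, only, none or still open, it means among the compounds named here.

Compound 1 `O=C(N/N=C/c1ccc(F)cc1)c1cn(C2CC2)c2cc(N3CCNCC3)c(F)cc2c1=O` is the starting point here. In a functional assay on HL-60 cells (Homo sapiens) for cytotoxicity, read by MTT assay (a higher number here means a weaker inhibitor, a lower number a stronger inhibitor), compound 1 gives 25000 nM. Compound 2 `O=C(N/N=C/c1ccc([N+](=O)[O-])cc1)c1cn(C2CC2)c2cc(N3CCNCC3)c(F)cc2c1=O` shares its core, and compound 2 gives 25000 nM, so the two stand level.

Compound 3 `COc1cc(/C=N/NC(=O)c2cn(C3CC3)c3cc(N4CCNCC4)c(F)cc3c2=O)cc(OC)c1OC` has not yet been measured. It carries 3,4,5-trimethoxyphenyl in place of 4-fluorophenyl on a carbon with a double bond to nitrogen.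

For the measured compounds named here, only one measured step bears on this change. Putting nitro in place of fluoro on an aromatic carbon gave no change at the digits printed from compound 1 to compound 2 (within the scatter). Going by the values given here, that is thin evidence, since that swap is a smaller one and no measured compound carries a 3,4,5-trimethoxyphenyl group. Among the compounds with values here, with compound 2 at 25000 nM, the only guide is a flat result, so no step beyond the scatter is expected in this assay, and the range must stay wide in both directions.

The expected step is a 1.3-fold lower number from compound 1 to compound 3 (0.10 log units; within the scatter), an estimate that stays within the scatter. The estimate for compound 3 is 20000 nM, with an expected range from 8000 nM to 40000 nM.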

Compound 3, half-maximal inhibitory concentration: 25000 nM
Compound 3: middle estimate off by 1.3-fold (0.10 log units), on the low side; the range from low to high includes it.
By their numbers in this assay, from the lowest: compounds 1, 2 and 3 (each within the scatter of the next).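

The new compound tests a far bigger swap at this place than the earlier pair did: 3,4,5-trimethoxyphenyl has 12 heavy atoms and 3 hydrogen-bond acceptors, where 4-fluorophenyl has 7 heavy atoms and 0 hydrogen-bond acceptors. Even so, in this assay this swap gives no change at the digits printed from compound 1 to compound 3 (within the scatter), and replacing 4-nitrophenyl with the same group gives no change at the digits printed from compound 2 to compound 3 (within the scatter). The flat result therefore no longer rests on one exchange of a single ring substituent, but holds across all three substituted phenyl groups at this place, although nothing available here explains why the read-out stays the same.

On these data alone, all three compounds keep a substituted phenyl ring on the carbon with a double bond to nitrogen, so it remains open whether an amine or a carboxylic acid on that ring, or a longer alkyl chain in place of the ring, would move the number in this assay. The shared core is also identical in all three, which leaves open whether this place would stay as flat on a different core.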